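A few compounds are considered here, and "the series" means these few. Any claim that something is new, unique, unknown or untested is made for them only; others in the source may bear on it.

Three close relatives sharing one core have been tested in a functional assay on MIA PaCa-2 cells (Homo sapiens) for cytotoxicity, read by WST assay, with a stated time of 48 h; on this read-out higher numbers stand for weaker inhibition and lower numbers for stronger inhibition. Compound 1 `COc1ccc2c(C(=O)/C(C#N)=C/c3c[nH]c4cc(F)ccc34)c[nH]c2c1` carries a methoxy on one ring and a fluoro on the other. In this assay compound 1 gives > 50000 nM, which is a limit of the assay rather than a number. Compound 2 `N#C/C(=C\c1c[nH]c2cc(F)ccc12)C(=O)c1c[nH]c2cc(F)ccc12` has a fluoro in place of the methoxy. In this assay compound 2 gives > 50000 nM, again a limit. Compound 3 `COc1ccc2[nH]cc(/C=C(\C#N)C(=O)c3c[nH]c4cc(F)ccc34)c2c1` carries the same two groups arranged differently. In this assay compound 3 gives > 50000 nM, also a limit. Among the compounds with values here, the one traceable step, a step that the two limits leave unreadable from compound 1 to compound 2, cannot be read because of the limit of > 50000 nM in this assay, at which 3 of the 3 values shown sit. Compound 1 thus stands where every measured compound stands: at the limit, with no number of its own. Compound 4 `COc1ccc2c(C(=O)/C(C#N)=C/c3c[nH]c4ccccc34)c[nH]c2c1` is the unmeasured member, and it differs from compound 1 as follows: hydrogen in place of fluoro on an aromatic carbon. Within the data shown here, no measured step shows what taking away a fluoro does; all three values shown are limits. With nothing pointing to a gain in potency, compound 4 is expected to give about 50000 nM, within a range of 20000 nM to 120000 nM, most probably reported once more as a limit. The expected step of a number no higher from compound 1 to compound 4 (the limit leaves the size open) means nothing beyond the scatter.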

Compound 4, half-maximal inhibitory concentration: > 50000 nM
Compound 4 ended at the assay's limit; the forecaster's own chance of this, stated with the estimate: 80%; the middle value lies on the limit itself.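

Swapping the fluoro for hydrogen between compound 1 and compound 4 gives no readable step, and no size can be put on it, because both compounds sit at the same limit of the assay: the limit of > 50000 nM in this assay, at which 4 of the 4 values shown sit. The compounds shown leave open how strongly any of them acts in this assay and which change to the shared core would bring a real number.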